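Methylating a Catechol Hydroxy on a Dibrominated Benzaldehyde

The source may report more compounds than this note shows. Statements on the series, on what has been measured and on what is new or still open speak of the compounds shown alone.

Measured compounds:
compound 1 `O=Cc1cc(O)c(O)c(Br)c1Br` — 30900 nM
compound 2 `COCc1cc(O)c(O)c(Br)c1Br` — 14600 nM

Both were tested in a functional assay on DLD-1 cells (Homo sapiens) for cytotoxicity, read by MTT assay, with a stated time of 96 h; on this read-out higher numbers stand for weaker inhibition and lower numbers for stronger inhibition. Among the two numbers, compound 1 stands highest, so it is the weaker inhibitor of the pair; its nearest neighbour is compound 2, which shows a 2.1-fold lower number from compound 1 to compound 2 (0.33 log units; beyond the scatter) step, modest but beyond the scatter.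

Compound 3 `COc1cc(C=O)c(Br)c(Br)c1O` differs from compound 1 by methyl in place of hydrogen on an oxygen on an aromatic ring. Among the compounds with values here, the only measured step, from compound 1 to compound 2, alters a different group on the ring, so it says nothing direct about what happens when one hydroxy is capped as a methoxy. Within the data shown here, with no comparable step to lean on, the safest expectation for this assay is a change of no more than the scatter in either direction. Compound 3 is therefore estimated at 32000 nM, with a range from 14000 nM to 75000 nM, which amounts to an expected step of a 1.0-fold higher number from compound 1 to compound 3 (0.02 log units; within the scatter) from compound 1.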

Compound 3, half-maximal inhibitory concentration: 91300 nM
Estimate against measurement, compound 3: 2.9-fold (0.46 log units) below; the whole stated range lies below it.
By their numbers in this assay, from the lowest: compound 2; then compound 1; then compound 3.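

In this assay, replacing the hydrogen on this ring oxygen with methyl, which turns hydroxy into methoxy, gives a 3.0-fold higher number from compound 1 to compound 3 (0.47 log units; beyond the scatter) and so weakens the inhibition by a modest margin beyond the scatter. This is the first change shown at a hydroxy oxygen, and the earlier change on an aromatic carbon, methoxymethyl in place of formyl, gave a 2.1-fold lower number from compound 1 to compound 2 (0.33 log units; beyond the scatter) and so moved the number the other way, which shows that the core of compound 1 does not respond in the same direction to every change. No evidence is available to explain why adding this methyl weakens the effect.

With only one group tried on this oxygen, the compounds shown cannot tell whether the loss belongs to methyl in particular or would also follow from a longer chain such as ethyl or a larger group such as benzyl. They also leave open whether the same methyl on the remaining hydroxy would shift the number as far, and whether a carboxylic acid or an amine in place of the formyl would change the picture.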